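The source may hold more compounds than are shown below. What is called first, only, known or untested is meant among the compounds shown, and "the series" means these compounds.

Compound 1, `[O-][n+]1ccc2[nH]cnc2c1`, gives only a limit of > 9 mg/kg in a functional assay on the whole organism (Pleural cavity) with Rattus norvegicus as the target; a higher number here means that more compound is needed for the effect, a lower number that less compound is needed.
Compound 2, `OC[C@H]1OC(n2cnc3c(Nc4ccccc4)nccc32)[C@H](O)[C@@H]1O`, gives only a limit of > 9 mg/kg in this assay.
Compound 3, `CN(C)c1nccc2c1ncn2[C@H]1C[C@H](O)[C@@H](CO)O1`, gives only a limit of > 9 mg/kg in this assay.

In this assay compound 2 stands at the limit and not at a number, and the whole set shares that position: the limit of > 9 mg/kg in this assay, at which 3 of the 3 values shown sit. Among the compounds with values here, no step between measured compounds is available to lean on. Compound 4, `OC[C@H]1OC(n2cnc3c(S)nccc32)[C@H](O)[C@@H]1O`, differs from compound 2 in one place: sulfanyl in place of anilino on an aromatic carbon. With every measured value resting at the limit, the change from compound 2 to compound 4 is expected to produce no step beyond the usual scatter, a step that the limit leaves unreadable from compound 2 to compound 4. Compound 4 is therefore estimated to give 15 mg/kg in this assay, within 5 mg/kg to 50 mg/kg, most likely reported again as a limit.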

Compound 4, dose for half-maximal effect: 9 mg/kg
The estimate for compound 4 lay 1.7-fold (0.22 log units) above the measured number; the range from low to high includes it.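

In this assay the exchange of anilino for sulfanyl on an aromatic carbon gives a number no higher from compound 2 to compound 4 (the limit leaves the size open). Compound 4 thus brings a readable number to this position, 9 mg/kg, the only one among the compounds shown. The size of the step cannot be read, and most of the set stays at one value: the limit of > 9 mg/kg in this assay, at which 3 of the 4 values shown sit.

Going by these compounds, how far anilino and sulfanyl truly lie apart remains open. So does what a methoxy group or a carboxylic acid on this same aromatic carbon would give in this assay.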